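Swapping a bis(cyclopropylmethyl)amino for piperidin-1-yl

The source may hold more compounds than are shown below. What is called first, only, known or untested is meant among the compounds shown, and "the series" means these compounds.

For the measured compounds named here, in an assay on CHO cells for displacement of a labelled ligand from corticotropin-releasing factor receptor 1 (Homo sapiens) (a lower number here means a stronger inhibitor, a higher number a weaker inhibitor), compound 3 `Cc1cc(C)c(-c2cn(C)c3nc(N(CC4CC4)CC4CC4)n(C)c(=O)c23)c(C)c1` gives 140 nM, the second highest of the three numbers so far. Compound 2 `CCCN(CCC)c1nc2c(c(-c3c(C)cc(C)cc3C)cn2C)c(=O)n1C` gives 120 nM, and compound 1 `CCN(CC)c1nc2c(c(-c3c(C)cc(C)cc3C)cn2C)c(=O)n1C` gives 7700 nM. The steps are a 55-fold lower number from compound 1 to compound 3 (1.74 log units; beyond the scatter) and a 1.2-fold higher number from compound 2 to compound 3 (0.07 log units; within the scatter), alongside a 64-fold lower number from compound 1 to compound 2 (1.81 log units; beyond the scatter). Compound 4 `Cc1cc(C)c(-c2cn(C)c3nc(N4CCCCC4)n(C)c(=O)c23)c(C)c1` differs from compound 3 by piperidin-1-yl in place of bis(cyclopropylmethyl)amino on an aromatic carbon. Going by the values given here, the closest precedent is the move from compound 1 to compound 3, where the diethylamino of compound 1 gave a far higher number; the new piperidin-1-yl is smaller than the departing group, so a higher number is expected for compound 4, with the step of a 7.1-fold higher number from compound 3 to compound 4 (0.85 log units; beyond the scatter). Compound 4 is expected at 1000 nM, between 200 nM and 5000 nM.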

Compound 4, half-maximal inhibitory concentration: 3800 nM
Compound 4: middle estimate off by 3.8-fold (0.58 log units), on the low side; the range from low to high includes it.
By their numbers in this assay, from the lowest: compounds 2 and 3 (each within the scatter of the next); then compound 4; then compound 1.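

Piperidin-1-yl on this aromatic carbon between two ring nitrogen atoms does not keep the level of the two open-chain amines, with a 27-fold higher number from compound 3 to compound 4 (1.43 log units; beyond the scatter) and a 32-fold higher number from compound 2 to compound 4 (1.50 log units; beyond the scatter). Against diethylamino the ring stays only modestly ahead, with a 2.0-fold lower number from compound 1 to compound 4 (0.31 log units; beyond the scatter), which places it near the weak end of these four compounds. Nothing available here accounts for this result. The compounds shown leave open whether pyrrolidin-1-yl or morpholin-4-yl would behave like piperidin-1-yl. They also leave open whether a longer chain, such as dibutylamino, would match compound 2 and compound 3.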